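A few compounds are considered here, and "the series" means these few. Any claim that something is new, unique, unknown or untested is made for them only; others in the source may bear on it.

Compound 1 `COc1ccc(-c2cc(/C=C/C(=O)c3ccc(N)cc3)[nH]n2)cc1` and compound 2 `COc1cc(-c2cc(/C=C/C(=O)c3ccc(Cl)c(Cl)c3)[nH]n2)cc(OC)c1OC` share a core and are tested in a functional assay on MCF7 cells (Homo sapiens) for inhibition, read by sulforhodamine B assay, with a stated time of 48 h; on this read-out higher numbers stand for lower toxicity in this test and lower numbers for higher toxicity in this test. In this assay compound 1 gives 34100 nM. For compound 2 the result is not a number but a limit of the test, > 100000 nM, and one of the two values recorded sits at this point (the limit of > 100000 nM in this assay, at which 1 of the 2 values shown sits). Compound 3 `COc1ccc(C(=O)/C=C/c2cc(-c3cc(OC)c(OC)c(OC)c3)n[nH]2)cc1` has not yet been measured here. Compound 3 differs from compound 2 in one place: 4-methoxyphenyl in place of 3,4-dichlorophenyl on a carbonyl carbon. Among the compounds with values here, no step between two measured compounds carries this change, so there is no direct basis to size it. Given that compound 2 only reached the limit > 100000 nM, the step from compound 2 to compound 3 is expected to be modest, an at least 1.4-fold lower number from compound 2 to compound 3 (0.15 log units; that floor lies within the scatter), in the direction of somewhat higher toxicity. On this basis compound 3 is expected to give about 70000 nM in this assay, within roughly 25000 nM to 200000 nM.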

Compound 3, concentration lethal to 50% of the cells: 7610 nM
Beside the measured number, compound 3's estimate is 9.2-fold (0.96 log units) above it; the measured number lies below the stated range.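

Putting 4-methoxyphenyl in place of 3,4-dichlorophenyl on a carbonyl carbon gives an at least 13-fold lower number from compound 2 to compound 3 (1.11 log units; beyond the scatter) in this assay, a large change toward higher toxicity in this test. Compound 1 and compound 2 differ in more than one place, so they could not show that this single position, with the rest of the molecule unchanged, can shift the read-out this far. The step gives only a minimum size, because compound 2 reached a limit of the test rather than a number: the limit of > 100000 nM in this assay, at which 1 of the 3 values shown sits.

The compounds shown do not tell whether removing the chlorine atoms or adding the methoxy group matters more. Going by these compounds, how an unsubstituted phenyl or a 4-hydroxyphenyl would behave on this carbonyl carbon, on the core of compound 3, also remains open.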